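The source may hold more compounds than are shown below. What is called first, only, known or untested is meant among the compounds shown, and "the series" means these compounds.

Compound 1 `COc1ccc(/C=C\c2cc(OC)c(OC)c(OC)c2)cc1OCc1ccc(C=O)cc1` gives 4800 nM in a functional assay on HeLa cells (Homo sapiens) for antiproliferative activity, read by CCK-8 assay, with a stated time of 48 h; on this read-out lower numbers stand for stronger inhibition and higher numbers for weaker inhibition.
Compound 2 `COc1ccc(/C=C\c2cc(OC)c(OC)c(OC)c2)cc1OCc1ccc(CN2CCCC[C@H]2C(=O)O)cc1` reaches only the limit of this assay, > 10000 nM.
Compound 3 `COc1ccc(/C=C\c2cc(OC)c(OC)c(OC)c2)cc1OCc1ccc(CN2CC[C@H](O)C2)cc1` gives 10500 nM in this assay.

Of the two numbers shown, compound 1 stands lowest; its nearest neighbour is compound 3, with a 2.2-fold higher number from compound 1 to compound 3 (0.34 log units; beyond the scatter). Compound 2 sits at a limit and not at a number, as the limit of > 10000 nM in this assay, at which 1 of the 3 values shown sits, records, so the step of an at least 2.0-fold higher number from compound 1 to compound 2 (0.31 log units; beyond the scatter) is read only as a floor, and the pair compound 2 to compound 3 gives a step that the limit leaves unreadable from compound 2 to compound 3.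

Compound 4 `COc1ccc(/C=C\c2cc(OC)c(OC)c(OC)c2)cc1OCc1ccc(CNCCN(C)C)cc1` differs from compound 1 by ((2-(dimethylamino)ethyl)amino)methyl in place of formyl on an aromatic carbon. Both measured steps from compound 1 bear on it: each replaced formyl with a nitrogen-bearing group on that same aromatic carbon, and each raised the number in this assay by a modest amount, a 2.2-fold higher number from compound 1 to compound 3 (0.34 log units; beyond the scatter) and an at least 2.0-fold higher number from compound 1 to compound 2 (0.31 log units; beyond the scatter). A rise of similar modest size, in the direction of weaker inhibition, is therefore expected for compound 4. Compound 4 is expected to give 9000 nM in this assay, within the range 4000 nM to 20000 nM. The step this estimate implies is a 1.9-fold higher number from compound 1 to compound 4 (0.27 log units; within the scatter).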

Compound 4, half-maximal inhibitory concentration: 9400 nM
Estimate against measurement, compound 4: 1.0-fold (0.02 log units) below; the range from low to high includes it.
By their numbers in this assay, from the lowest: compounds 1, 4 and 3 (each within the scatter of the next, the first and the last beyond it).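

Among these compounds, the open chain ((2-(dimethylamino)ethyl)amino)methyl, which has no ring, is the first nitrogen-bearing replacement for formyl on this aromatic carbon whose step stays inside the scatter (a 2.0-fold higher number from compound 1 to compound 4 (0.29 log units; within the scatter)), though that step is nearly the size of the earlier ones. Exchanging the 3-hydroxypyrrolidin-1-yl of compound 3 for this chain separates nothing in this assay (a 1.1-fold lower number from compound 3 to compound 4 (0.05 log units; within the scatter)), so a ring on this nitrogen is not needed for a value of this order. The comparison with compound 2 gives only a floor (an at least 1.0-fold lower number from compound 2 to compound 4 (0.02 log units; that floor lies within the scatter)) and no size: the limit of > 10000 nM in this assay, at which 1 of the 4 values shown sits.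

The compounds shown leave open whether a morpholine, a primary amine or a longer chain at this position would give a lower number than formyl. They also leave open whether an amide in place of the amine would change the reading.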